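Notes on the amide aryl group: compound 2 to compound 3

The compounds below may be only part of what the source reports. "The series", "measured", "known", "first", "only" and "open" are said of these compounds alone.

Among the compounds with values here, in an assay on isolated protein for inhibition of histone deacetylase 4 (Homo sapiens), with a stated time of 1 h (on this read-out lower numbers stand for stronger inhibition and higher numbers for weaker inhibition), compound 2 `O=C(COc1ccc2cc(/C=C3/SC(=O)NC3=O)ccc2c1)Nc1ccccc1` gives 2100 nM, the lowest of the two numbers measured so far. Its nearest neighbour is compound 1 `O=C(COc1ccc2cc(/C=C3/SC(=O)NC3=O)ccc2c1)Nc1ccccn1`, which in this assay gives 17000 nM. The step between them, an 8.1-fold lower number from compound 1 to compound 2 (0.91 log units; beyond the scatter), goes with the change of pyridin-2-yl to phenyl on the amide-type nitrogen. Compound 3 `Cc1cccc(NC(=O)COc2ccc3cc(/C=C4/SC(=O)NC4=O)ccc3c2)n1` is not yet measured. It differs from compound 2 by 6-methylpyridin-2-yl in place of phenyl on an amide-type nitrogen. Within the data shown here, the only measured step bearing on this change is an 8.1-fold lower number from compound 1 to compound 2 (0.91 log units; beyond the scatter), which runs in the opposite sense: exchanging pyridin-2-yl for phenyl lowered the number. Returning to a pyridin-2-yl, here carrying a methyl, is therefore expected to raise the number again, though a methyl on that ring has no precedent in this set, so the size is uncertain. For compound 3 the estimate in this assay is 9000 nM, range 3000 nM to 30000 nM, meaning an expected step of a 4.3-fold higher number from compound 2 to compound 3 (0.63 log units; beyond the scatter).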

Compound 3, half-maximal inhibitory concentration: 1100 nM
The estimate for compound 3 lay 8.2-fold (0.91 log units) above the measured number; measured number below the stated range.
By their numbers in this assay, from the lowest: compounds 3 and 2 (each within the scatter of the next); then compound 1.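

In this assay, the pyridin-2-yl ring on the amide-type nitrogen does not by itself go with a high number: methyl in place of hydrogen on an aromatic carbon gives a 15-fold lower number from compound 1 to compound 3 (1.19 log units; beyond the scatter), a large step from a single added methyl. Set against phenyl, 6-methylpyridin-2-yl gives a 1.9-fold lower number from compound 2 to compound 3 (0.28 log units; within the scatter), so these two groups cannot be told apart on this read-out, and the earlier phenyl-over-pyridin-2-yl step holds only for the ring without the methyl. Nothing available accounts for the effect of the methyl.

The compounds shown leave open whether ethyl, methoxy or chlorine in place of the methyl on the pyridine ring would give a similar step. They also leave open whether a methyl on the phenyl ring of compound 2 would shift the number at all.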